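A few compounds are considered here, and "the series" means these few. Any claim that something is new, unique, unknown or untested is made for them only; others in the source may bear on it.

Compound 1, `O=C(O)c1ccc(-c2csc(-c3ccccc3F)n2)cc1`, in a physicochemical assay for solubility, using the shake flask method, measured as kinetic solubility, at pH 7.4; on this read-out higher numbers stand for higher solubility and lower numbers for lower solubility: 38400 nM
Compound 2, `COC(=O)c1cccc(-c2cnc(Nc3cccc(F)c3)o2)c1`: < 1000 nM
Compound 3, `COC(=O)c1cccc(-c2cnc(Nc3ccc(F)cc3)o2)c1`: < 1000 nM

In this assay, within the data shown here, compound 1 gives 38400 nM, the only number among the three. For compound 2 the result is a limit of the assay, < 1000 nM. For compound 3 likewise only a limit is reported, < 1000 nM. The step that the two limits leave unreadable from compound 2 to compound 3 therefore cannot be read in size or direction. Compound 3 thus stands at the limit of < 1000 nM in this assay, at which 2 of the 3 values shown sit, with no number of its own.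

Compound 4, `CNC(=O)c1cccc(-c2cnc(Nc3ccc(F)cc3)o2)c1`, differs from compound 3 by methylamino in place of methoxy on a carbonyl carbon. No measured step touches this group: the one step shown, a step that the two limits leave unreadable from compound 2 to compound 3, concerns the fluorophenyl and is unreadable. The expectation for compound 4 rests only on compound 3 sitting at the limit in this assay, so any estimate is loose. Compound 4 is expected to give 1500 nM in this assay, within 400 nM to 6000 nM. This corresponds to an expected step of an at least 1.5-fold higher number from compound 3 to compound 4 (0.17 log units; that floor lies within the scatter), which cannot be sized against a limit.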

Compound 4, solubility: 3100 nM
For compound 4 the middle estimate is 2.1-fold (0.32 log units) below the measured one; the range from low to high includes it.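

Methylamino in place of methoxy on a carbonyl carbon gives, in this assay, an at least 3.1-fold higher number from compound 3 to compound 4 (0.49 log units; beyond the scatter). The only earlier step, on the fluorophenyl, cannot be read, so this is the first change shown between two close analogues that yields a number rather than a limit, and it shows that this carbonyl position can move the read-out beyond the scatter. The true size of the step remains unknown, and only its floor can be given, because compound 3 has no number of its own: the limit of < 1000 nM in this assay, at which 2 of the 4 values shown sit.

As far as these compounds go, what a plain amino, a dimethylamino or a longer ethylamino group would give on the same carbonyl carbon remains open. Also open, from the compounds shown here alone, is whether the methylamino step would be of similar size on compound 2, whose fluorine sits elsewhere on the fluorophenyl.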